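Swapping a Branched Ether for Methylsulfanyl in Compound 4

This account rests on a few compounds, and the source may have more. Where it says the series, first, only, none or still open, it means among the compounds named here.

Of the compounds shown here, three built on one shared core have been tested in an assay on cells with melanin-concentrating hormone receptor 1 (Homo sapiens) as the target, read by radioligand binding; a lower number here means a stronger inhibitor, a higher number a weaker inhibitor. Compound 1 `CCOCCOc1cccc2ccc(N)nc12` carries an ethoxy group on its side chain. In this assay compound 1 reaches only a limit, > 2000 nM, so no number is known for it. Compound 2 `CCCOc1cccc2ccc(N)nc12` gives 1100 nM in this assay. Compound 3 `COC(C)(C)CCOc1cccc2ccc(N)nc12` gives 132 nM in this assay, the lower of the two numbers that exist; its nearest neighbour is compound 2, and the step of an 8.3-fold lower number from compound 2 to compound 3 (0.92 log units; beyond the scatter) is modest. The step of an at least 15-fold lower number from compound 1 to compound 3 (1.18 log units; beyond the scatter) is large, though it rests on one limit (the limit of > 2000 nM in this assay, at which 1 of the 3 values shown sits).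

Compound 4 `CSCCOc1cccc2ccc(N)nc12` has not yet been measured. It differs from compound 3 by methylsulfanyl in place of 1-methoxy-1-methylethyl on a saturated chain carbon, two bonds along the chain from an oxygen on an aromatic ring. The two steps that bear on this change, an 8.3-fold lower number from compound 2 to compound 3 (0.92 log units; beyond the scatter) and an at least 15-fold lower number from compound 1 to compound 3 (1.18 log units; beyond the scatter), both show that bringing in the 1-methoxy-1-methylethyl group lowered the number, and compound 4 takes that group away again for a small methylsulfanyl group, closer in size to the methyl of compound 2. The number is therefore expected to rise, by about a 6.8-fold higher number from compound 3 to compound 4 (0.83 log units; beyond the scatter) in this assay. For compound 4 the estimate is 900 nM, with a likely range from 300 nM to 2500 nM.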

Compound 4, half-maximal inhibitory concentration: > 2000 nM
Compound 4 ended at the assay's limit; the forecaster's own chance of this, stated with the estimate: 25%; middle value at least 2.2-fold (0.34 log units) away from the limit.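

At this place on the chain, methylsulfanyl in place of 1-methoxy-1-methylethyl gives an at least 15-fold higher number from compound 3 to compound 4 (1.18 log units; beyond the scatter) in this assay, so the low number does not carry over to this smaller group. Set against methyl, methylsulfanyl gives an at least 1.8-fold higher number from compound 2 to compound 4 (0.25 log units; that floor lies within the scatter) in this assay, so these compounds offer no sign that methylsulfanyl does better than methyl, and that floor cannot say how far apart the two really are. The step from compound 1 to compound 4 cannot be read, and only a limit is available for each of them: the limit of > 2000 nM in this assay, at which 2 of the 4 values shown sit.

The compounds shown leave open whether the low number of compound 3 depends on the methoxy oxygen of its branched group or on the branching alone, a question that a tert-butyl group at the same place would address. On these data alone, how an amine, a carboxylic acid or a longer unbranched chain on this saturated chain carbon would read in this assay also remains open.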